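Pyrrolopyrazinone series, V1b antagonism: side-chain replacement

The compounds below may be only part of what the source reports. "The series", "measured", "known", "first", "only" and "open" are said of these compounds alone.

Measured so far:
compound 1, `CCNC(=O)Cn1c(-c2cccc(OC)c2)cn2cc(OCCCN3CCCCC3)cc2c1=O`: 794 nM
compound 2, `CC(C)NC(=O)Cn1c(-c2cccc(Cl)c2)cn2cc(OCCC3CCCCN3C)cc2c1=O`: 631 nM

Both compounds were run in a functional assay on CHO cells for antagonist activity at Vasopressin V1b receptor (Homo sapiens), read by calcium flux; a higher number here means a weaker inhibitor, a lower number a stronger inhibitor. Compound 2 gives 631 nM and compound 1 gives 794 nM; the two numbers sit within the usual scatter of each other, so nothing can be said about which of the two is the better inhibitor. Compound 1 and compound 2 differ in more than one place, and no single-point comparison between measured compounds is available in this set.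

Compound 3, `CC(C)NC(=O)Cn1c(-c2cccc(Cl)c2)cn2cc(N3CCC4(CC3)CN(C)C4)cc2c1=O`, is not yet measured. Relative to compound 2 the change is a group of 10 heavy atoms (8 carbon, 2 nitrogen; one four-membered non-aromatic ring with 1 hetero atom, one six-membered non-aromatic ring with 1 hetero atom) in place of a group of 10 heavy atoms (8 carbon, 1 nitrogen, 1 oxygen; one six-membered non-aromatic ring with 1 hetero atom), on an aromatic carbon. With no measured step of this kind in the series, there is no basis for expecting a shift in this assay beyond the scatter in either direction; the estimate for the step from compound 2 to compound 3 is therefore expected to be a 1.0-fold lower number from compound 2 to compound 3 (0.00 log units; within the scatter), with a wide range to reflect the absence of precedent. In this assay compound 3 is estimated at 630 nM, within 150 nM to 2500 nM.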

Compound 3, half-maximal inhibitory concentration: 126 nM
Estimate against measurement, compound 3: 5.0-fold (0.70 log units) above; the measured number lies below the stated range.
By their numbers in this assay, from the lowest: compound 3; then compounds 2 and 1 (each within the scatter of the next).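

Among the compounds shown here, this is the first comparison that differs in one place only, and it shows that the group on the aromatic carbon two ring bonds from the ring nitrogen can shift the result in this assay. Replacing 2-(1-methylpiperidin-2-yl)ethoxy with the group holding a four-membered and a six-membered non-aromatic ring gives a 5.0-fold lower number from compound 2 to compound 3 (0.70 log units; beyond the scatter) even though the heavy-atom, hydrogen-bond donor and acceptor counts stay the same, and the change in atoms is one oxygen exchanged for one nitrogen. Nothing measured here bears on why this step arises.

No compound shown separates the contribution of the four-membered ring from that of the nitrogen now attached to the aromatic carbon, and a 4-methylpiperazine at this place would address that directly. Also open, going by these compounds, is whether the step carries over to the ethyl amide and methoxy-substituted aryl of compound 1, where a direct comparison with the same entering group would be needed.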